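The source may hold more compounds than are shown below. What is called first, only, known or untested is meant among the compounds shown, and "the series" means these compounds.

Measured compounds in a functional assay on HOP-92 cells (Homo sapiens) for cytotoxicity, read by sulforhodamine B assay, with a stated time of 48 h; a higher number here means a weaker inhibitor of growth, a lower number a stronger inhibitor of growth:

- Compound 1 `ClCc1ccc(Cn2cnc3c(Cl)ncnc32)cc1`: in this assay compound 1 gives 66100 nM.
- Compound 2 `Nc1nc(Cl)c2ncn(Cc3ccc(CCl)cc3)c2n1`: in this assay compound 2 gives > 100000 nM, a limit of the assay and not a number.
- Compound 3 `ClCc1ccccc1Cn1cnc2c(Cl)ncnc21`: in this assay compound 3 gives 4260 nM.

From compound 1 to compound 2 the change is amino in place of hydrogen on an aromatic carbon; the step is an at least 1.5-fold higher number from compound 1 to compound 2 (0.17 log units; that floor lies within the scatter), its true size open because compound 2 sits at the limit of > 100000 nM in this assay, at which 1 of the 3 values shown sits. Compound 3 has the same atoms as compound 1, joined differently; the difference between the two cores is not broken down here. In this assay compound 3 gives the lower of the two numbers, and the gap to compound 1 lies beyond the scatter.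

Compound 4 `Nc1nc(Cl)c2ncn(Cc3ccccc3CCl)c2n1` is not yet measured. From compound 3 it differs by amino in place of hydrogen on an aromatic carbon, the same change as from compound 1 to compound 2, at the same place. Within the data shown here, on the single measured instance, a weakening is expected: a step of a 3.1-fold higher number from compound 3 to compound 4 (0.48 log units; beyond the scatter) in this assay, resting on an at least 1.5-fold higher number from compound 1 to compound 2 (0.17 log units; that floor lies within the scatter). Compound 4 is therefore estimated at 13000 nM, between 5000 nM and 50000 nM.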

Compound 4, concentration for total growth inhibition: 30900 nM
For compound 4 the middle estimate is 2.4-fold (0.38 log units) below the measured one; the range from low to high includes it.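

In this assay, amino in place of hydrogen on an aromatic carbon gives a 7.3-fold higher number from compound 3 to compound 4 (0.86 log units; beyond the scatter), a weakening on the core of compound 3 that lies beyond the scatter. Compound 2 gives > 100000 nM, a limit of the assay and not a number, so the earlier step is known only as a floor. The two steps therefore show no reversal of the change on either core, but they do not show that it carries over with the same size, and two cores cannot establish a rule for the series: the same change on two cores in this assay, an at least 1.5-fold higher number (0.17 log units; that floor lies within the scatter) from compound 1 to compound 2 and a 7.3-fold higher number (0.86 log units; beyond the scatter) from compound 3 to compound 4; the limit leaves it open whether they differ.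

Still open, on these data alone, is whether a methylamino or a hydroxyl group in place of the amino group would weaken growth inhibition in the same way. Also open, as far as these compounds go, is whether the amino step would hold on either core if a methoxy group replaced the chloro group on the same ring.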